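The source may report more compounds than this note shows. Statements on the series, on what has been measured and on what is new or still open speak of the compounds shown alone.

Compound 1 `OCc1cn(CCNc2nonc2/C(=N/O)Nc2ccc(F)c(Br)c2)nn1` and compound 2 `CCC(C)(O)c1cn(CCNc2nonc2/C(=N/O)Nc2ccc(F)c(Br)c2)nn1` share one core and differ only in the group carried on the five-membered aromatic ring. In an assay on isolated protein for inhibition of Indoleamine 2,3-dioxygenase 1 (Homo sapiens) (a lower number here means a stronger inhibitor, a higher number a weaker inhibitor), compound 1 gives 77 nM, and compound 2 gives 53 nM. Compound 2 holds the lowest of the two numbers, yet the step of a 1.5-fold lower number from compound 1 to compound 2 (0.16 log units; within the scatter) is within the scatter, so the two compounds cannot be told apart on these data. Compound 3 `OCCOCc1cn(CCNc2nonc2/C(=N/O)Nc2ccc(F)c(Br)c2)nn1` is the next compound: (2-hydroxyethoxy)methyl in place of 1-hydroxy-1-methylpropyl on an aromatic carbon. Among the compounds with values here, the only measured step that bears on this position, a 1.5-fold lower number from compound 1 to compound 2 (0.16 log units; within the scatter), exchanged one group carrying a hydrogen-bond donor for another at the same place without a change beyond the scatter. A similar outcome is expected now, so compound 3 is estimated at 65 nM, with a range from 30 nM to 140 nM. The expected step of a 1.2-fold higher number from compound 2 to compound 3 (0.09 log units; within the scatter) would stay within the scatter.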

Compound 3, half-maximal inhibitory concentration: 28 nM
Beside the measured number, compound 3's estimate is 2.3-fold (0.37 log units) above it; the whole stated range lies above it.
By their numbers in this assay, from the lowest: compounds 3, 2 and 1 (each within the scatter of the next, the first and the last beyond it).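

In this assay, within the data shown here, the step of a 2.8-fold lower number from compound 1 to compound 3 (0.44 log units; beyond the scatter) is the first at this position to pass beyond the scatter, although it is modest: it places 2-hydroxyethyl on the oxygen of the hydroxymethyl group. The step of a 1.9-fold lower number from compound 2 to compound 3 (0.28 log units; within the scatter) stays within the scatter, so the (2-hydroxyethoxy)methyl and 1-hydroxy-1-methylpropyl groups cannot be told apart on these data, even though they differ in shape and the former carries a second hydrogen-bond acceptor. The position therefore tolerates this longer chain with no loss, and the gain is seen only against hydroxymethyl, while no measurement given here accounts for that gain. The compounds shown leave open whether the hydroxyl of the (2-hydroxyethoxy)methyl group matters. A methyl ether, an amine or a carboxylic acid in its place, or a longer chain of the same kind, could settle that.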